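A few compounds are considered here, and "the series" means these few. Any claim that something is new, unique, unknown or untested is made for them only; others in the source may bear on it.

In an ADME assay on L02 cells (Homo sapiens) for antiproliferative activity, read by MTT assay, with a stated time of 48 h (on this read-out lower numbers stand for stronger inhibition and higher numbers for weaker inhibition), compound 1 `N#CC1=C(N)Oc2c(c3nc4ccccc4nc3c3ccccc23)C12C(=O)N(Cc1cnnn1-c1cccc(Cl)c1)c1ccccc12` gives 35200 nM. For compound 2 `Cc1ccccc1-n1nncc1CN1C(=O)C2(C(C#N)=C(N)Oc3c(N)cc4nc5ccccc5nc4c32)c2ccccc21` the assay reports only a limit, > 50000 nM. Compound 3 `Cc1cccc(-n2nncc2CN2C(=O)C3(C(C#N)=C(N)Oc4c(N)cc5nc6ccccc6nc5c43)c3ccccc32)c1` likewise stops at a limit, > 50000 nM, so its place among the numbers shown is known only as that limit, which one further value shares. The step that the two limits leave unreadable from compound 2 to compound 3 therefore cannot be read. Compound 4 `CCc1ccccc1-n1nncc1CN1C(=O)C2(C(C#N)=C(N)Oc3c(N)cc4nc5ccccc5nc4c32)c2ccccc21` differs from compound 3 by 2-ethylphenyl in place of 3-methylphenyl on an aromatic nitrogen. Going by the values given here, the single measured step at this position gives no size to lean on, and the limit of > 50000 nM in this assay, at which 2 of the 3 values shown sit, marks where two of the three values sit. No shift beyond the scatter is expected in this assay for compound 4. Compound 4 is therefore estimated at 50000 nM, between 30000 nM and 90000 nM. That estimate means an expected step of a number no higher from compound 3 to compound 4 (the limit leaves the size open).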

Compound 4, half-maximal inhibitory concentration: 22900 nM
The estimate for compound 4 lay 2.2-fold (0.34 log units) above the measured number, and the stated range ends above it.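

Going by these compounds alone, on the aromatic nitrogen, 2-ethylphenyl gives the first readable change at this position in this assay, with an at least 2.1-fold lower number from compound 3 to compound 4 (0.33 log units; beyond the scatter). The methyl added on the saturated chain carbon bound to an aromatic carbon gives an at least 2.1-fold lower number from compound 2 to compound 4 (0.33 log units; beyond the scatter). Compound 2 and compound 3 are limits and not numbers, so the full size of neither step can be read: the limit of > 50000 nM in this assay, at which 2 of the 4 values shown sit. The compounds shown leave open whether a longer chain such as propyl, or an amine, in place of the ethyl group would lower the number further, and whether 3-ethylphenyl would match 2-ethylphenyl.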